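The source may report more compounds than this note shows. Statements on the series, on what has been measured and on what is new or still open speak of the compounds shown alone.

Measured in a physicochemical assay for lipophilicity, at pH 7.4 (a lower number here means a more polar compound, a higher number a more lipophilic compound), each entry a limit and not a number:
- Compound 1 `CNC(=O)c1cc(C)n(Cc2cc(Cl)ccc2OCc2ccccc2)n1` gives > 3.7 as a limit.
- Compound 2 `Cc1cc(C(=O)Nc2ccccc2)nn1Cc1cc(Cl)ccc1OCc1ccccc1` gives > 3.7 as a limit.
- Compound 3 `Cc1cc(C(=O)NCc2cccnc2)nn1Cc1cc(Cl)ccc1OCc1ccccc1` gives > 3.7 as a limit.

Compound 3 stands at the limit of > 3.7 in this assay, at which 3 of the 3 values shown sit, and has no number. Compound 4 `CC(=O)Nc1cc(C)n(Cc2cc(Cl)ccc2OCc2ccccc2)n1` is reached through (acetamido in place of ((pyridin-3-yl)methyl)carbamoyl on an aromatic carbon), acetamido in place of ((pyridin-3-yl)methyl)carbamoyl on an aromatic carbon. The nearest measured steps, a step that the two limits leave unreadable from compound 1 to compound 3 and a step that the two limits leave unreadable from compound 2 to compound 3, fix neither size nor direction. Compound 1 holds its limit of > 3.7 with only methyl on the amide-type nitrogen, so compound 4 is expected near that limit. No step beyond the scatter is expected, and a step that the limit leaves unreadable from compound 3 to compound 4 is the estimate. For compound 4 the estimated value is 4, with an expected range from 3.5 to 4.5.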

Compound 4, distribution coefficient: > 3.7
Compound 4: a limit, no number; the forecaster's own chance of this, stated with the estimate: 70%; the middle value does not contradict the limit.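

In this assay compound 4 gives > 3.7, a limit and not a number, so its steps from compound 1, compound 2 and compound 3 cannot be read. The compounds shown leave open the size and direction of every change among them, all resting on one limit: the limit of > 3.7 in this assay, at which 4 of the 4 values shown sit.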